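Replacing 2-oxopyrrolidin-1-yl with methyl(pyridin-3-yl)amino

A few compounds are considered here, and "the series" means these few. Any claim that something is new, unique, unknown or untested is made for them only; others in the source may bear on it.

Measured so far in a physicochemical assay for solubility, read by LC-MS, in phosphate buffer, with a stated time of 24 h, at pH 7.4; a higher number here means a more soluble compound, a lower number a less soluble compound:
- compound 1 `CN(c1ncco1)c1cnc(NCc2c(F)ccc3c2CCO3)n2cnnc12`: 67000 nM
- compound 2 `O=C1CCCN1c1cnc(NCc2c(F)ccc3c2CCO3)n2cnnc12`: 640000 nM

Of these two, compound 2 stands highest, at 640000 nM. Compound 3 `CN(c1cccnc1)c1cnc(NCc2c(F)ccc3c2CCO3)n2cnnc12` differs from it by methyl(pyridin-3-yl)amino in place of 2-oxopyrrolidin-1-yl on an aromatic carbon. Among the measured compounds shown here, one measured step bears on this change: a 9.6-fold higher number from compound 1 to compound 2 (0.98 log units; beyond the scatter). That step is modest but beyond the scatter, and it also removes a methyl(aryl)amino group in favour of 2-oxopyrrolidin-1-yl. Compound 3 restores a group of that methylamino kind, so a step of similar size towards a lower number is expected in this assay. The estimated change is a 13-fold lower number from compound 2 to compound 3 (1.11 log units; beyond the scatter). The expected value for compound 3 is 50000 nM, with an estimated range of 12000 nM to 200000 nM.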

Compound 3, solubility: 47000 nM
Compound 3: the middle estimate sits 1.1-fold (0.03 log units) above what was measured; low and high end bracket the measured number.
By their numbers in this assay, from the lowest: compounds 3 and 1 (each within the scatter of the next); then compound 2.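

In this assay, the gap from 2-oxopyrrolidin-1-yl at this aromatic carbon holds for a second methyl(aryl)amino group, with a 14-fold lower number from compound 2 to compound 3 (1.13 log units; beyond the scatter) on the shared core. Exchanging the ring on the nitrogen gives a 1.4-fold lower number from compound 1 to compound 3 (0.15 log units; within the scatter) and so does not separate pyridin-3-yl from 1,3-oxazol-2-yl. No evidence here gives a reason for the gap. The compounds shown leave open whether an open-chain amide such as acetamido, or a saturated amine such as morpholin-4-yl, would stand with compound 2 or with compound 1 and compound 3.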